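A few compounds are considered here, and "the series" means these few. Any claim that something is new, unique, unknown or untested is made for them only; others in the source may bear on it.

Compound 1 `C=CC1=C(C(=O)NC2CCCCC2)C(c2ccc(OC)cc2)OC1` was tested in a functional assay on QGY7701 cells (Homo sapiens) for cytotoxicity, read by MTT assay, with a stated time of 24 h (on this read-out higher numbers stand for weaker inhibition and lower numbers for stronger inhibition), where compound 1 gives > 100000 nM, which is a limit of the assay rather than a number, so on the numbers shown compound 1 stands at the weak end, at the limit of > 100000 nM in this assay, at which 1 of the 3 values shown sits. Its companions are compound 2 `C=CC1=C(C(=O)Nc2ccccc2)C(c2ccc(F)cc2)OC1`, which gives 46700 nM in this assay, and compound 3 `C=CC1=C(C(=O)NC2CCCCC2)C(c2ccc(F)cc2)OC1`, which gives 40500 nM. Compound 4 `C=CC1=C(C(=O)Nc2ccc(OCC)cc2)C(c2ccc(OC)cc2)OC1` differs from compound 1 by 4-ethoxyphenyl in place of cyclohexyl on an amide-type nitrogen. Among the measured compounds shown here, only one measured step bears on this change: exchanging the group on the amide-type nitrogen gave a 1.2-fold lower number from compound 2 to compound 3 (0.06 log units; within the scatter). For the measured compounds named here, no measured step covers the ethoxy, so little change is expected, a number no higher from compound 1 to compound 4 (the limit leaves the size open). Compound 4 is therefore estimated at 100000 nM, with a range from 40000 nM to 300000 nM.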

Compound 4, half-maximal inhibitory concentration: > 100000 nM
Compound 4: only a limit was reported; the forecaster's own chance of this, stated with the estimate: 60%; the middle value sits exactly at the limit.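

Compound 1 and compound 4 both reach only a limit of the assay, so the step between them cannot be read: the limit of > 100000 nM in this assay, at which 2 of the 4 values shown sit.

The compounds shown leave open whether 4-ethoxyphenyl in place of cyclohexyl on the amide-type nitrogen changes the number in this assay at all.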